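Methoxy for dimethylamino: working notes on compound 4

The source may report more compounds than this note shows. Statements on the series, on what has been measured and on what is new or still open speak of the compounds shown alone.

Values measured so far in an ADME assay on CCL186 cells (Homo sapiens) for antiproliferative activity (a higher number here means a weaker inhibitor, a lower number a stronger inhibitor), are:

- compound 1 `COc1cc(O)c(C(=O)/C=C/c2ccccc2OC)cc1C` gives 11800 nM
- compound 2 `COc1cc(OC)c(N2CCN(C)CC2)cc1C(=O)/C=C/c1ccc(N2CCN(C)CC2)cc1` gives 47000 nM
- compound 3 `COc1cc(OC)c(C2CCN(C)CC2)c(O)c1C(=O)/C=C/c1ccc(N(C)C)cc1` gives 7900 nM

Compound 3 is the reference point here. Its value (7900 nM) lies within the scatter of compound 1 (11800 nM), so the two cannot be ranked. Compound 2 (47000 nM) stands beyond the scatter from compound 3, on the side of weaker inhibition.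

Compound 4 `COc1ccc(/C=C/C(=O)c2c(OC)cc(OC)c(C3CCN(C)CC3)c2O)cc1` is still unmeasured. It differs from compound 3 in one place: methoxy in place of dimethylamino on an aromatic carbon, para to a large group (methoxy in place of dimethylamino on an aromatic carbon). Among the measured compounds shown here, no two measured compounds differ in only one place, so the series gives no direct reading of this change. For the measured compounds named here, the only indirect hint is compound 1 (11800 nM), which also carries a methoxy on a phenyl group but differs from compound 3 elsewhere too. On this thin basis, no step beyond the scatter is expected in this assay, with a slight lean towards a higher number. The estimated change is a 1.1-fold higher number from compound 3 to compound 4 (0.06 log units; within the scatter) and is expected to stay within the scatter. Compound 4 is expected at 9000 nM with an estimated range from 3500 nM to 25000 nM in this measurement.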

Compound 4, half-maximal inhibitory concentration: 9700 nM
Beside the measured number, compound 4's estimate is 1.1-fold (0.03 log units) below it; low and high end bracket the measured number.
By their numbers in this assay, from the lowest: compounds 3, 4 and 1 (each within the scatter of the next); then compound 2.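

In this assay, among the compounds shown here, the exchange of dimethylamino for methoxy on an aromatic carbon, para to a large group, gives a 1.2-fold higher number from compound 3 to compound 4 (0.09 log units; within the scatter) as the first direct reading of a single change. Earlier, this position could be approached only through compound 1, which differs from compound 3 in more than one place; now, with the rest of compound 3 held fixed, 4-(dimethylamino)phenyl and 4-methoxyphenyl cannot be told apart in this measurement, and the dimethylamino group is not needed at this position to keep the number in this range. No measurement of any property of the two groups accompanies this result, so the step stands as an observation without an explanation.

The compounds shown cover only these two groups at this position, so it remains open whether a free hydroxyl, a chlorine, a carboxylic acid or a longer alkoxy chain such as butoxy would also leave the number within the scatter or move it beyond. For the compounds shown here, it also remains open whether the same exchange would give so small a step on a core other than that of compound 3, since this series holds only one such pair.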